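Swapping an Ether Link for a Benzylamine

A few compounds are considered here, and "the series" means these few. Any claim that something is new, unique, unknown or untested is made for them only; others in the source may bear on it.

Compound 1, `Nc1cc(N)c2nc(-c3ccccc3)c(Oc3ccc(F)cc3)nc2c1`, was tested in a functional assay on LOX IMVI cells (Homo sapiens) for inhibition, read by sulforhodamine B assay, with a stated time of 48 h; on this read-out higher numbers stand for lower toxicity in this test and lower numbers for higher toxicity in this test. In this assay compound 1 gives < 100000 nM, which is a limit of the assay rather than a number. That is where compound 1 stands among the values shown: two of the three sit at the same limit, as noted in the limit of < 100000 nM in this assay, at which 2 of the 3 values shown sit. Compound 2, `CCOC(=O)[C@H](CCC(=O)O)NC(=O)c1ccc(Oc2nc3cc(N)cc(N)c3nc2-c2ccccc2)cc1`, shares the core of compound 1 and is larger; in this assay compound 2 gives 57500 nM. Compound 3, `CCOC(=O)[C@H](CCC(=O)O)NC(=O)c1ccc(CNc2nc3cc(N)cc(N)c3nc2-c2ccccc2)cc1`, also shares that core, and in this assay compound 3 gives < 100000 nM, again a limit of the assay and not a number. Within the data shown here, none of these measured compounds differ from one another in a single place, so no measured step can be drawn between them, and the values of compound 2 and compound 3 show only that one is a number and the other a limit in the same region.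

Compound 4, `Nc1cc(N)c2nc(-c3ccccc3)c(NCc3ccc(F)cc3)nc2c1`, has not yet been measured. It differs from compound 1 in one place: (4-fluorobenzyl)amino in place of 4-fluorophenoxy on an aromatic carbon. Among the measured compounds shown here, with no measured step to lean on, the change from compound 1 to compound 4 is expected to bring no shift beyond the scatter, giving a step that the limit leaves unreadable from compound 1 to compound 4. Compound 4 is therefore estimated at 60000 nM, within a range from 20000 nM to 100000 nM.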

Compound 4, concentration lethal to 50% of the cells: 6610 nM
For compound 4 the middle estimate is 9.1-fold (0.96 log units) above the measured one; the measured number lies below the stated range.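

No new step can be read from compound 4, because compound 1, the compound it differs from in one place, stands at a limit and not at a number in this assay: the limit of < 100000 nM in this assay, at which 2 of the 4 values shown sit.

The compounds shown leave open how large a change (4-fluorobenzyl)amino in place of 4-fluorophenoxy brings in this assay on the shared core.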